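From ethoxy to hydroxy on the shared core

The source may report more compounds than this note shows. Statements on the series, on what has been measured and on what is new or still open speak of the compounds shown alone.

Measured in a functional assay on KBVIN cells (Homo sapiens) for cytotoxicity, read by sulforhodamine B assay, with a stated time of 72 h; on this read-out higher numbers stand for an effect only at larger amounts of compound and lower numbers for an effect already at smaller amounts:
- compound 1 `Cc1cccc(-c2cc3occ(C)c3c(=O)o2)c1`: 40 uM
- compound 2 `CCOc1cccc(-c2cc3occ(C)c3c(=O)o2)c1`: > 74.1 uM, a limit

Compound 2 stands only at a limit, (the limit of > 74.1 uM in this assay, at which 1 of the 2 values shown sits). Compound 3 `Cc1coc2cc(-c3cccc(O)c3)oc(=O)c12` differs from it by hydrogen in place of ethyl on an oxygen on an aromatic ring. Going by the values given here, the only measured step, an at least 1.8-fold higher number from compound 1 to compound 2 (0.26 log units; that floor lies within the scatter), places ethoxy where methyl stood, so it bears on this change only loosely. Among the compounds with values here, compound 1 at 40 uM is the sole number available, so a modest move to a lower number is expected in this assay. The expected step is an at least 1.8-fold lower number from compound 2 to compound 3 (0.26 log units; that floor lies within the scatter). For compound 3 the estimated value is 40 uM, with a range of 15 uM to 90 uM.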

Compound 3, concentration for half-maximal effect: 60.3 uM
Compound 3: middle estimate off by 1.5-fold (0.18 log units), on the low side, and the stated range covers the measured number.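

In this assay, hydrogen in place of ethyl on an oxygen on an aromatic ring gives an at least 1.2-fold lower number from compound 2 to compound 3 (0.08 log units; that floor lies within the scatter). From the compounds shown here alone, compound 2 is known only as a limit, so the true size of this step remains unknown: the limit of > 74.1 uM in this assay, at which 1 of the 3 values shown sits. Going from methyl to hydroxy gives a 1.5-fold higher number from compound 1 to compound 3 (0.18 log units; within the scatter), so this assay does not tell these two groups apart.

The compounds shown leave open whether an amine or a carboxylic acid at this place would move the number beyond the scatter. They also leave open how a longer chain on the oxygen would read.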